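From 6-methoxypyridin-3-yl to 3-carboxy-4-methoxyphenyl

The source may hold more compounds than are shown below. What is called first, only, known or untested is meant among the compounds shown, and "the series" means these compounds.

Compound 1 `COc1ccc(-c2cncc3[nH]c(=O)n(Cc4cc(OC)c(OC)c(OC)c4)c23)cc1` gives > 20000 nM (a limit)
Compound 2 `COc1ccc(-c2cc3c(cn2)[nH]c(=O)n3-c2cc(OC)c(OC)c(OC)c2)cn1` gives 1220 nM
Compound 3 `COc1ccc(-n2c(=O)[nH]c3cnc(-c4cc(OC)c(OC)c(OC)c4)cc32)cc1O` gives > 20000 nM (a limit)

In a functional assay on A549 cells (Homo sapiens) for antiproliferative activity, read by MTT assay, with a stated time of 48 h (on this read-out lower numbers stand for stronger inhibition and higher numbers for weaker inhibition), compound 2 gives 1220 nM and is the only one of the three with a number. Compound 1 and compound 3 report no number, only the limit of > 20000 nM in this assay, at which 2 of the 3 values shown sit, in each case.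

Compound 4 `COc1ccc(-c2cc3c(cn2)[nH]c(=O)n3-c2cc(OC)c(OC)c(OC)c2)cc1C(=O)O` has not yet been measured. It carries 3-carboxy-4-methoxyphenyl in place of the 6-methoxypyridin-3-yl of compound 2, on an aromatic carbon next to the ring nitrogen 3-carboxy-4-methoxyphenyl in place of 6-methoxypyridin-3-yl on an aromatic carbon and the rest of the structure stays the same.

Among the measured compounds shown here, no measured pair here shows a change at this place, so the size of the step has to be judged without one. Starting from compound 2 at 1220 nM a move beyond the scatter towards weaker inhibition in this assay is expected, and a 4.1-fold higher number from compound 2 to compound 4 (0.61 log units; beyond the scatter) is the estimated size of that move. The estimate for compound 4 is 5000 nM with an expected range from 1500 nM to 20000 nM in this measurement.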

Compound 4, half-maximal inhibitory concentration: 1280 nM
For compound 4 the middle estimate is 3.9-fold (0.59 log units) above the measured one; measured number below the stated range.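

In this assay, placing 3-carboxy-4-methoxyphenyl in place of 6-methoxypyridin-3-yl on this aromatic carbon next to the ring nitrogen gives a 1.0-fold higher number from compound 2 to compound 4 (0.02 log units; within the scatter), so the two compounds cannot be told apart. Among the compounds shown here, the earlier compounds offered no pair differing at this place, and this step shows for the first time that a ring of carbon only bearing a carboxy group can stand here and still give a number rather than a limit. Nothing measured here accounts for this result.

As far as these compounds go, whether the carboxy group or the ring carbon that replaces the ring nitrogen matters on its own stays open, since both differ at once in this step. An amine or a methyl ester in place of the carboxy group would be needed to tell how far this position reaches, and steps involving the limits cannot be read.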